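The source may report more compounds than this note shows. Statements on the series, on what has been measured and on what is new or still open speak of the compounds shown alone.

Measured so far:
compound 1 `CCCCCCOc1ccc2c(=O)c(-c3ccc(O)cc3)coc2c1`: 1500 nM
compound 2 `CCOC(=O)CCCCOc1ccc2c(=O)c(-c3ccc(O)cc3)coc2c1`: 240 nM
compound 3 `O=C(O)COc1ccc2c(=O)c(-c3ccc(O)cc3)coc2c1`: 1200 nM

All three were tested in an assay (Cricetulus griseus) for inhibition of aldehyde dehydrogenase, mitochondrial (Homo sapiens); on this read-out higher numbers stand for weaker inhibition and lower numbers for stronger inhibition. Compound 1 has the highest number of the three; compound 3 sits close to it, the step being a 1.3-fold lower number from compound 1 to compound 3 (0.10 log units; within the scatter), while compound 2 stands apart, with a 6.3-fold lower number from compound 1 to compound 2 (0.80 log units; beyond the scatter). Compound 4 `C=CCOc1ccc2c(=O)c(-c3ccc(O)cc3)coc2c1` differs from compound 1 in one place: vinyl in place of pentyl on a saturated chain carbon bound to an oxygen on an aromatic ring. Two measured steps start from compound 1. The step of a 1.3-fold lower number from compound 1 to compound 3 (0.10 log units; within the scatter) replaces the whole pentyl at the same place and yet stays within the scatter. The step of a 6.3-fold lower number from compound 1 to compound 2 (0.80 log units; beyond the scatter) is larger, but it keeps the chain and changes it four bonds along from the oxygen, so it says less about a shortening. A change of no more than the scatter is therefore expected for compound 4, estimated as a 1.2-fold lower number from compound 1 to compound 4 (0.06 log units; within the scatter). Compound 4 is expected to give 1300 nM, between 500 nM and 3500 nM.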

Compound 4, half-maximal inhibitory concentration: 180 nM
For compound 4 the middle estimate is 7.2-fold (0.86 log units) above the measured one, and the stated range ends above it.
By their numbers in this assay, from the lowest: compounds 4 and 2 (each within the scatter of the next); then compounds 3 and 1 (each within the scatter of the next).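

Cutting the chain from hexyloxy to allyloxy has a large effect at this position (an 8.3-fold lower number from compound 1 to compound 4 (0.92 log units; beyond the scatter)), which the earlier steps did not suggest. Allyloxy also differs clearly from the carboxy group of compound 3 (a 6.7-fold lower number from compound 3 to compound 4 (0.82 log units; beyond the scatter)), yet it stays level with the much longer ester chain (a 1.3-fold lower number from compound 2 to compound 4 (0.12 log units; within the scatter)), so chain length alone does not order these compounds. Nothing measured here explains these differences. Still open, on these data alone, is whether the double bond or the shorter chain matters, which a saturated propyl chain on the same oxygen would separate.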